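A few compounds are considered here, and "the series" means these few. Any claim that something is new, unique, unknown or untested is made for them only; others in the source may bear on it.

Values in a functional assay on HL-60 cells (Homo sapiens) for inhibition, read by CCK-8 assay, with a stated time of 48 h (on this read-out higher numbers stand for weaker inhibition and lower numbers for stronger inhibition), for the measured members of the series:

- compound 1 `O=S(=O)(NCCNC(=S)Nc1cc(C(F)(F)F)cc(C(F)(F)F)c1)c1ccc(-c2ccccc2OCc2cccc(O)c2)s1`: only a limit of the assay, > 50000 nM
- compound 2 `O=C(NCCNS(=O)(=O)c1ccc(-c2ccccc2OCc2cccc(O)c2)s1)Nc1cc(C(F)(F)F)cc(C(F)(F)F)c1`: 4000 nM
- compound 3 `O=S(=O)(NCCNC(=S)Nc1cc(C(F)(F)F)cc(C(F)(F)F)c1)c1ccc(-c2ccccc2O[C@H]2CC[C@@H](O)CC2)s1`: 2600 nM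

Compound 1 and compound 3 differ in one place, (4-hydroxycyclohexyl in place of 3-hydroxybenzyl on an oxygen on an aromatic ring), and the step is an at least 19-fold lower number from compound 1 to compound 3 (1.28 log units; beyond the scatter). Its size rests on (the limit of > 50000 nM in this assay, at which 1 of the 3 values shown sits), so only a lower bound of the gain is known. Compound 2 and compound 1 share most of their structure, but the difference between the two cores is not broken down here; compound 2 and compound 3 sit within the scatter of each other.

Compound 4 `O=C(NCCNS(=O)(=O)c1ccc(-c2ccccc2O[C@H]2CC[C@@H](O)CC2)s1)Nc1cc(C(F)(F)F)cc(C(F)(F)F)c1` is the unmeasured partner of compound 2, differing by 4-hydroxycyclohexyl in place of 3-hydroxybenzyl on an oxygen on an aromatic ring. The place is the same in both pairs, so this is the same change as that from compound 1 to compound 3. For compound 4 the expected step beside the earlier one is a 5.0-fold lower number from compound 2 to compound 4 (0.70 log units; beyond the scatter), resting on the large gain seen from compound 1 to compound 3 an at least 19-fold lower number from compound 1 to compound 3 (1.28 log units; beyond the scatter), tempered since that gain is only bounded by a limit. The estimate for compound 4 in this assay is 800 nM, expected between 200 nM and 4000 nM.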

Compound 4, half-maximal inhibitory concentration: 3100 nM
Compound 4: middle estimate off by 3.9-fold (0.59 log units), on the low side, within the range that was stated.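

In this assay, the change from 3-hydroxybenzyl to 4-hydroxycyclohexyl does not carry over in size from the core of compound 1 to the core of compound 2: the same change on two cores in this assay, an at least 19-fold lower number (1.28 log units; beyond the scatter) from compound 1 to compound 3 and a 1.3-fold lower number (0.11 log units; within the scatter) from compound 2 to compound 4, at least 14-fold (1.17 log units) apart, beyond the scatter of two such steps On the core of compound 2, the change gives a 1.3-fold lower number from compound 2 to compound 4 (0.11 log units; within the scatter), so no gain can be read there. The earlier step has no exact size, so the gap between the two steps is only a bound, and these two pairs do not show what sets the cores apart: the limit of > 50000 nM in this assay, at which 1 of the 4 values shown sits.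

On these data alone, whether the two cores also part ways for other groups on this oxygen remains open. A 4-aminocyclohexyl or a 4-carboxycyclohexyl group in the same place on both cores would test this.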